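The source may report more compounds than this note shows. Statements on the series, on what has been measured and on what is new or still open speak of the compounds shown alone.

Compound 1 (`CC(CO)Nc1nc(N)nc2c1ncn2[C@H]1C[C@H](N=[N+]=[N-])[C@@H](CO)O1`) gives > 100000 nM in an ADME assay on Vero cells (Chlorocebus sabaeus) for cytotoxicity, with a stated time of 5 days (a higher number here means a weaker inhibitor, a lower number a stronger inhibitor), and this is a limit of the assay, not a number. Compound 2 (`[N-]=[N+]=N[C@H]1C[C@H](n2cnc3c(NCCO)nc(N)nc32)O[C@@H]1CO`) gives > 100000 nM, which is also a limit. So compound 2 has no exact value, and the only other value shown is no more exact. The next compound, compound 3 (`C=CCN(C)c1nc(N)nc2c1ncn2[C@H]1C[C@H](N=[N+]=[N-])[C@@H](CO)O1`), carries allyl(methyl)amino in place of (2-hydroxyethyl)amino on an aromatic carbon, next to the ring nitrogen: allyl(methyl)amino in place of (2-hydroxyethyl)amino on an aromatic carbon. For the measured compounds named here, the only measured step is a step that the two limits leave unreadable from compound 1 to compound 2, so it offers no size to carry over. Going by the values given here, the sole guide is the limit of > 100000 nM in this assay, at which 2 of the 2 values shown sit. The expected change is therefore none beyond the scatter, with a modest move towards stronger inhibition allowed as a precaution. The estimated step is an at least 1.1-fold lower number from compound 2 to compound 3 (0.04 log units; that floor lies within the scatter). For compound 3 the expected value is 90000 nM, with an estimated range from 30000 nM to 100000 nM.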

Compound 3, half-maximal inhibitory concentration: 32000 nM
Compound 3: the middle estimate sits 2.8-fold (0.45 log units) above what was measured; the measured number falls inside the stated range.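

In this assay, allyl(methyl)amino in place of (2-hydroxyethyl)amino on this aromatic carbon, next to the ring nitrogen, gives an at least 3.1-fold lower number from compound 2 to compound 3 (0.49 log units; beyond the scatter), and in place of (1-(hydroxymethyl)ethyl)amino it gives an at least 3.1-fold lower number from compound 1 to compound 3 (0.49 log units; beyond the scatter). For the compounds shown here, the step between compound 1 and compound 2 cannot be read, so these are the first signs that the group at this position can move the number beyond the scatter. Both sizes are only floors, and the comparison rests on limits of the assay: the limit of > 100000 nM in this assay, at which 2 of the 3 values shown sit.

The change alters several things at once, since the entering group has a double bond, an added methyl and no hydrogen-bond donors, so the compounds shown do not tell which of these matters. A saturated propylamino chain or a dimethylamino group at the same place would help separate them.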